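This account rests on a few compounds, and the source may have more. Where it says the series, first, only, none or still open, it means among the compounds named here.

In a functional assay on HCT-116 cells (Homo sapiens) for inhibition, read by MTT assay, with a stated time of 2 days (a higher number here means that more compound is tolerated, a lower number that less compound is tolerated), compound 1 (`Nc1ccccc1NC(=O)CCCNCC(=O)Nc1ccc(Cl)cc1`) gives > 100000 nM, which is a limit of the assay and not a number. Compound 2 (`Nc1ccccc1NC(=O)CCCNCC(=O)Nc1cccc([N+](=O)[O-])c1`) gives > 100000 nM, again a limit. Compound 3 (`Nc1ccccc1NC(=O)c1ccc(NCC(=O)Nc2ccc([N+](=O)[O-])cc2)cc1`) gives > 100000 nM, also a limit. Compound 2 therefore has no number of its own, and the whole picture so far is the limit of > 100000 nM in this assay, at which 3 of the 3 values shown sit.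

Compound 4 (`Nc1ccccc1NC(=O)CCCNCC(=O)Nc1ccccc1Cl`) has not yet been measured. It carries 2-chlorophenyl in place of 3-nitrophenyl on an amide-type nitrogen. Among the measured compounds shown here, the only measured step that bears on this change is a step that the two limits leave unreadable from compound 1 to compound 2, at the same kind of amide-type nitrogen. No size carries over from it, so no change beyond the scatter is expected in this assay. The expected step is a number no higher from compound 2 to compound 4 (the limit leaves the size open). Compound 4 is estimated at 100000 nM, with an expected range from 40000 nM to 200000 nM, and the assay will most likely report only a limit again.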

Compound 4, concentration lethal to 50% of the cells: > 100000 nM
Compound 4: a limit, no number; the forecaster's own chance of this, stated with the estimate: 85%; the middle value lies on the limit itself.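

In this assay compound 4 gives > 100000 nM, which is a limit and not a number. Its steps from compound 1 and compound 2 therefore cannot be read. The compounds shown leave open whether the groups on the amide-type nitrogen differ at all in this assay, because every value sits at one limit: the limit of > 100000 nM in this assay, at which 4 of the 4 values shown sit.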